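A few compounds are considered here, and "the series" means these few. Any claim that something is new, unique, unknown or untested is made for them only; others in the source may bear on it.

Compound 1, with the structure `CCC(C)C(NC(=O)NO)C(=O)NC1CCCCC1`, was tested in a functional assay on HeLa cells (Homo sapiens) for inhibition; a higher number here means a weaker inhibitor, a lower number a stronger inhibitor. In this assay compound 1 gives only a limit, > 100000 nM, and not a measured number; it is the limit of > 100000 nM in this assay, at which 1 of the 2 values shown sits. A second compound from the same set, compound 2 with the structure `CCC(C)C(NC(=O)n1nnc2ccccc21)C(=O)NC1CCCC1`, gives 82300 nM in this assay. Compound 2 differs from compound 1 in more than one place, so the two values show only that both are weak inhibitors.

The compound not yet measured, compound 3 with the structure `CCC(C)C(NC(=O)NO)C(=O)NC1CCCC1`, differs from compound 1 in a single place: cyclopentyl in place of cyclohexyl on an amide-type nitrogen. Within the data shown here, no measured pair in this set shows the effect of such a change in this assay, so the expectation rests on compound 1 alone. The step from compound 1 to compound 3 is expected to be a number no higher from compound 1 to compound 3 (the limit leaves the size open), that is, no change beyond the scatter, and the result may well come back as a limit again. Compound 3 is therefore estimated to give about 100000 nM in this assay, with a likely range from 40000 nM to 300000 nM.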

Compound 3, half-maximal inhibitory concentration: > 100000 nM
Compound 3 gave a limit, no number (the forecaster's own chance of this, stated with the estimate: 60%); the middle value lies on the limit itself.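

Compound 1 and compound 3 each return only a limit in this assay, not a number, so no step can be read between them: the limit of > 100000 nM in this assay, at which 2 of the 3 values shown sit.

Whether cyclopentyl in place of cyclohexyl on an amide-type nitrogen changes inhibition at all in this assay stays open with the compounds shown.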